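Little to go on from a hydroxy to a hydroxypyrrolidine

This account rests on a few compounds, and the source may have more. Where it says the series, first, only, none or still open, it means among the compounds named here.

Measured in a functional assay on HeLa cells (Homo sapiens) for antiproliferative activity, read by CCK-8 assay, with a stated time of 48 h; a lower number here means a stronger inhibitor, a higher number a weaker inhibitor:
- compound 1 `COc1ccc(/C=C\c2cc(OC)c(OC)c(OC)c2)cc1OCc1ccc(CNC(C)(C)C(=O)O)cc1`: > 10000 nM (a limit)
- compound 2 `COc1ccc(/C=C\c2cc(OC)c(OC)c(OC)c2)cc1OCc1ccc(CN2CCCC[C@@H]2C(=O)O)cc1`: > 10000 nM (a limit)
- compound 3 `COc1ccc(/C=C\c2cc(OC)c(OC)c(OC)c2)cc1OCc1ccc(CO)cc1`: 7600 nM

Compound 3 holds the only actual number among these. The other two values are limits. The step followed here leads from compound 3 to compound 4 `COc1ccc(/C=C\c2cc(OC)c(OC)c(OC)c2)cc1OCc1ccc(CN2CC[C@@H](O)C2)cc1`: 3-hydroxypyrrolidin-1-yl in place of hydroxy on a saturated chain carbon bound to an aromatic carbon. In words, 3-hydroxypyrrolidin-1-yl takes the place of hydroxy on a saturated chain carbon bound to an aromatic carbon.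

Two measured steps changed the same place, and both end at compound 3: an at least 1.3-fold lower number from compound 1 to compound 3 (0.11 log units; that floor lies within the scatter) and an at least 1.3-fold lower number from compound 2 to compound 3 (0.11 log units; that floor lies within the scatter). Neither gives a true size, because of the limit of > 10000 nM in this assay, at which 2 of the 3 values shown sit. Neither brings in the 3-hydroxypyrrolidin-1-yl group itself. Resting on compound 3 at 7600 nM and those two floors, no step beyond the scatter is expected in this assay, in either direction. The estimated change is a 1.1-fold lower number from compound 3 to compound 4 (0.04 log units; within the scatter). For compound 4 the expected value is 7000 nM, with an estimated range of 2000 nM to 20000 nM.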

Compound 4, half-maximal inhibitory concentration: > 10000 nM
Compound 4 was reported as a limit; the forecaster's own chance of this, stated with the estimate: 30%; at least 1.4-fold (0.15 log units) between middle value and limit.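

In this assay compound 4 gives > 10000 nM, which is a limit of the assay and not a number. Compounds 1 and 2 carry a carboxylic acid in the group on this saturated chain carbon, whereas the 3-hydroxypyrrolidin-1-yl group of compound 4 has none, and that group also yields no measured number. The one step with a floor is an at least 1.3-fold higher number from compound 3 to compound 4 (0.11 log units; that floor lies within the scatter), so the size of the change from hydroxy stays unknown, and the steps from compound 1 and compound 2 to compound 4 cannot be read, because the values sit at one limit: the limit of > 10000 nM in this assay, at which 3 of the 4 values shown sit.

Still open, from the compounds shown here alone, is whether a smaller group at this place, such as a plain amino group or a methoxy, would give a readable value. Going by these compounds, it is equally open whether a morpholin-4-yl ring would do so.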